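This account rests on a few compounds, and the source may have more. Where it says the series, first, only, none or still open, it means among the compounds named here.

Measured so far:
Compound 1, `COc1cccc2cc(-c3nn[nH]n3)cnc12`, in a functional assay on the whole organism (strain Sprague-Dawley) for inhibition, with Rattus norvegicus as the target (a higher number here means that more compound is needed for the effect, a lower number that less compound is needed), compound 1 gives 2.5 mg/kg.
Compound 2, `COc1ccc2ncc(C(=O)O)cc2c1`, in this assay compound 2 gives > 5 mg/kg, which is a limit of the assay, not a number.
Compound 3, `O=C(O)c1cnc2ccc(C(F)(F)F)cc2c1`, in this assay compound 3 gives > 25 mg/kg, also a limit rather than a number.

Compound 1 and compound 2 share no single counted difference; how their two cores differ is not broken down here. From compound 2 to compound 3 the change is trifluoromethyl in place of methoxy on an aromatic carbon, and in this assay it made a step that the two limits leave unreadable from compound 2 to compound 3, since both ends sit at the limit of > 5 mg/kg in this assay, at which 1 of the 3 values shown sits, and (the limit of > 25 mg/kg in this assay, at which 1 of the 3 values shown sits).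

The unmeasured compound 4 is `FC(F)(F)c1cccc2cc(-c3nn[nH]n3)cnc12`. From compound 1 to compound 4 the change is trifluoromethyl in place of methoxy on an aromatic carbon; the group sits ortho and meta to a fused ring here, meta and para there, so this is the same kind of change, not the same. No readable step supports a firm expectation. Compound 4 is expected to give 10 mg/kg, between 3 mg/kg and 40 mg/kg, an estimated step of a 4.0-fold higher number from compound 1 to compound 4 (0.60 log units; beyond the scatter) from compound 1.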

Compound 4, minimum effective dose: < 25 mg/kg
Compound 4: only a limit was reported; the forecaster's own chance of this, stated with the estimate: 50%; the middle value lies beyond the limit too.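

In this assay compound 4 gives < 25 mg/kg, which is a limit of the assay and not a number. Among these compounds, no step from compound 1 to compound 4 can be read from it. The compounds shown leave open how much trifluoromethyl in place of methoxy changes the dose needed.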